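The source may hold more compounds than are shown below. What is called first, only, known or untested is meant among the compounds shown, and "the series" means these compounds.

Measured so far:
- Compound 1, `Fc1ccc(-c2ccc3c(NCCCNCc4ccco4)ccnc3c2)cc1`: 32000 nM
- Compound 2, `CC(C)CCc1ccc2c(NCCCNCc3ccco3)ccnc2c1`: 4200 nM
- Compound 3, `CC(C)(C)c1ccc(-c2ccc3c(NCCCNCc4ccco4)ccnc3c2)cc1`: 32000 nM

In a physicochemical assay for solubility, with a stated time of 18 h, at pH 7.4 (a higher number here means a more soluble compound, a lower number a less soluble compound), compound 3 stands level with compound 1, the two together giving the highest numbers of the three. Between them there is no change at the digits printed from compound 1 to compound 3 (within the scatter). The only clear movement among the measured compounds is a 7.6-fold higher number from compound 2 to compound 3 (0.88 log units; beyond the scatter), so the aryl group on the shared core sits with a higher solubility than the isopentyl chain.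

Compound 4, `CN(C)c1cccc(Oc2ccc3c(NCCCNCc4ccco4)ccnc3c2)c1`, is the unmeasured compound. It differs from compound 3 in one place: 3-(dimethylamino)phenoxy in place of 4-(tert-butyl)phenyl on an aromatic carbon.

For the measured compounds named here, none of the measured steps exchanges one aryl group for an aryl ether, so the closest guidance is indirect. The step of no change at the digits printed from compound 1 to compound 3 (within the scatter) shows that swapping one substituent on the pendant ring for another left this assay unchanged, while a 7.6-fold higher number from compound 2 to compound 3 (0.88 log units; beyond the scatter) shows that the aryl-bearing compounds reach the higher numbers. Compound 4 keeps an aromatic ring at that position, so it is expected to remain in the range of compound 3, with a 1.3-fold higher number from compound 3 to compound 4 (0.10 log units; within the scatter) as the estimated step. For compound 4 the estimate is 40000 nM, within 12000 nM to 120000 nM.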

Compound 4, solubility: 14500 nM
Beside the measured number, compound 4's estimate is 2.8-fold (0.44 log units) above it; low and high end bracket the measured number.
By their numbers in this assay, from the lowest: compound 2; then compound 4; then compounds 1 and 3 (each within the scatter of the next).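

In this assay, keeping an aromatic ring at this position does not by itself hold the number at the top of the range: 3-(dimethylamino)phenoxy carries a six-membered aromatic ring of carbon only, as 4-(tert-butyl)phenyl does, yet the exchange gives a 2.2-fold lower number from compound 3 to compound 4 (0.34 log units; beyond the scatter). Against the 4-fluorophenyl group the exchange gives a 2.2-fold lower number from compound 1 to compound 4 (0.34 log units; beyond the scatter), and against the isopentyl chain it gives a 3.5-fold higher number from compound 2 to compound 4 (0.54 log units; beyond the scatter), so the new group falls clearly between the earlier aryl groups and the chain. The entering group brings one nitrogen, one oxygen and two hydrogen-bond acceptors, but no measurement here accounts for the lower number.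

On these data alone, whether that lower number goes with the ether oxygen or with the dimethylamino group stays open. A plain phenoxy group and a 3-(dimethylamino)phenyl group on the same carbon would separate the two.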